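This account rests on a few compounds, and the source may have more. Where it says the series, first, only, none or still open, it means among the compounds named here.

Compound 3 `Cc1ccc(S/C(=C/c2ccc[nH]2)C(=O)c2ccc(Cl)cc2)cc1` carries a 1H-pyrrol-2-yl group on a double-bonded chain carbon bound to a double-bonded chain carbon. In a functional assay on DU-145 cells (Homo sapiens) for inhibition, read by trypan blue exclusion, with a stated time of 96 h (on this read-out lower numbers stand for stronger inhibition of growth and higher numbers for weaker inhibition of growth), compound 3 gives 10000 nM. Compound 2 `Cc1ccc(S/C(=C/c2c[nH]c3ccccc23)C(=O)c2ccc(Cl)cc2)cc1`, with 1H-indol-3-yl at that place, gives 10000 nM, so there is no change at the digits printed from compound 2 to compound 3 (within the scatter), and the two stand together as the lowest numbers of the three measured. Compound 1 `Cc1ccc(S/C(=C/c2ccc(Br)cc2)C(=O)c2ccc(Cl)cc2)cc1`, which carries 4-bromophenyl there, gives 25000 nM; that is a 2.5-fold lower number from compound 1 to compound 3 (0.40 log units; beyond the scatter) and a 2.5-fold lower number from compound 1 to compound 2 (0.40 log units; beyond the scatter).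

Compound 4 `Cc1ccc(S/C(=C/c2ccc(Cl)cc2Cl)C(=O)c2ccc(Cl)cc2)cc1` differs from compound 3 in one place: 2,4-dichlorophenyl in place of 1H-pyrrol-2-yl on a double-bonded chain carbon bound to a double-bonded chain carbon. The step that bears on this is the move from compound 1 to compound 3, where exchanging 4-bromophenyl for 1H-pyrrol-2-yl lowered the number. Compound 4 goes back toward a halogenated phenyl group, so the expectation is a rise in this assay of about the same size, a 2.2-fold higher number from compound 3 to compound 4 (0.34 log units; beyond the scatter), in the direction of compound 1. Compound 4 is therefore expected to give about 22000 nM, within a range of 10000 nM to 50000 nM.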

Compound 4, concentration for 50% growth inhibition: 10000 nM
For compound 4 the middle estimate is 2.2-fold (0.34 log units) above the measured one, and the stated range covers the measured number.
By their numbers in this assay, from the lowest: compounds 2, 3 and 4 (each within the scatter of the next); then compound 1.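

In this assay, a phenyl group carrying halogen at this place does not by itself bring a higher number: there is no change at the digits printed from compound 3 to compound 4 (within the scatter) and no change at the digits printed from compound 2 to compound 4 (within the scatter), yet still a 2.5-fold lower number from compound 1 to compound 4 (0.40 log units; beyond the scatter). The hydrogen-bond donor of 1H-pyrrol-2-yl is thus not required to reach this level, since 2,4-dichlorophenyl, with 0 hydrogen-bond donors, stands level with it. No measurement shown explains why 4-bromophenyl and 2,4-dichlorophenyl part ways.

The compounds shown leave open whether that gap follows the bromine or the two chlorines, which a 4-chlorophenyl group would help to separate. They also leave open what happens at this place without an aromatic ring, for example with an amine or a carboxylic acid on a longer chain.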